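The compounds below may be only part of what the source reports. "The series", "measured", "known", "first", "only" and "open" are said of these compounds alone.

Measured compounds in this set:
compound 1 `COc1ccc2c(c1)[C@@H](O)CN(C)C2`, > 100000 nM
compound 2 `CN1Cc2ccc(OCCc3ccccc3)cc2[C@@H](O)C1`, > 50000 nM
compound 3 `CN1Cc2ccc(OCC3CCCCC3)cc2[C@@H](O)C1`, 65600 nM

Within the data shown here, in an ADME assay on Vero cells (Chlorocebus sabaeus) for cytotoxicity, read by sulforhodamine B assay, with a stated time of 72 h (on this read-out lower numbers stand for stronger inhibition and higher numbers for weaker inhibition), compound 3 gives 65600 nM and is the only compound of the three with a number rather than a limit. Compound 1 gives > 100000 nM, which is a limit of the assay. Compound 2 gives > 50000 nM, also a limit. Among the measured compounds shown here, of the single-point steps, only the one from compound 1 to compound 3 can be read: an at least 1.5-fold lower number from compound 1 to compound 3 (0.18 log units; that floor lies within the scatter), a floor that lies within the usual scatter. The step from compound 1 to compound 2 is a step that the two limits leave unreadable from compound 1 to compound 2, and the step from compound 2 to compound 3 is a step that the limit leaves unreadable from compound 2 to compound 3, both unreadable because of the limits the limit of > 100000 nM in this assay, at which 1 of the 3 values shown sits, and (the limit of > 50000 nM in this assay, at which 1 of the 3 values shown sits).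

Compound 4 `CN1Cc2ccc(OCC3CCNCC3)cc2[C@@H](O)C1` differs from compound 3 in one place: piperidin-4-yl in place of cyclohexyl on a saturated chain carbon bound to an oxygen on an aromatic ring. For the measured compounds named here, no measured step covers this change; the nearest comparison, from compound 2 to compound 3, is unreadable. The expectation for compound 4 in this assay therefore rests on compound 3 alone, and the expected step from compound 3 is a 1.2-fold higher number from compound 3 to compound 4 (0.09 log units; within the scatter), that is, no change beyond the scatter, with a real chance that only a limit is reported. For compound 4 the estimated value is 80000 nM, with a range from 30000 nM to 200000 nM.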

Compound 4, half-maximal inhibitory concentration: > 100000 nM
Compound 4: a limit, no number; the forecaster's own chance of this, stated with the estimate: 50%; at least 1.2-fold (0.09 log units) between middle value and limit.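

In this assay, piperidin-4-yl in place of cyclohexyl on a saturated chain carbon bound to an oxygen on an aromatic ring gives an at least 1.5-fold higher number from compound 3 to compound 4 (0.18 log units; that floor lies within the scatter). Among these compounds, compound 4 carries a limit and no number, so the floor of this step does not establish a difference beyond the scatter; what is new is only that a ring with 1 hetero atom and 1 hydrogen-bond donor at this position does not yield a number in this assay, whereas the carbon-only ring of compound 3 does. The other two new steps to compound 4 cannot be read, because both ends of each are limits: the limit of > 100000 nM in this assay, at which 2 of the 4 values shown sit, and the limit of > 50000 nM in this assay, at which 1 of the 4 values shown sits.

As far as these compounds go, with a limit on one side, the true size of the change from cyclohexyl to piperidin-4-yl remains open. Also open, from the compounds shown here alone, is whether a carboxylic acid, a dimethylamino group or a longer chain at this saturated chain carbon would return a number in this assay or stay at a limit.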